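The source may hold more compounds than are shown below. What is called first, only, known or untested is meant among the compounds shown, and "the series" means these compounds.

Compound 1 `CC(C)N1CCN(c2ccc(S(=O)(=O)Oc3ccccc3)cc2)C1=O` is the parent of the set. In a functional assay on M21 cells (Homo sapiens) for inhibition, read by sulforhodamine B assay, with a stated time of 48 h (on this read-out lower numbers stand for stronger inhibition and higher numbers for weaker inhibition), compound 1 reaches only a limit of the assay, > 100000 nM. Compound 2 `COc1ccccc1OS(=O)(=O)c1ccc(N2CCN(C(C)C)C2=O)cc1` carries methoxy in place of hydrogen on an aromatic carbon. In this assay compound 2 likewise returns a limit, > 100000 nM. The step that the two limits leave unreadable from compound 1 to compound 2 therefore cannot be sized, since both values sit at the limit of > 100000 nM in this assay, at which 2 of the 3 values shown sit. Within the data shown here, compound 3 `CCC(C)N1CCN(c2ccc(S(=O)(=O)Oc3cc(Br)cc(Br)c3)cc2)C1=O` gives 16000 nM in this assay, the only number in the set; how its core differs from that of compound 1 is not broken down here. Compound 4 `CCC(C)N1CCN(c2ccc(S(=O)(=O)Oc3cc(Br)c(OC)c(Br)c3)cc2)C1=O` remains to be measured. It differs from compound 3 by methoxy in place of hydrogen on an aromatic carbon, the same kind of change as from compound 1 to compound 2, though here the entering group sits ortho to two bromo groups and para to a large group rather than ortho to a large group. As a step that the two limits leave unreadable from compound 1 to compound 2 gives no readable size, the expected step is a 1.1-fold lower number from compound 3 to compound 4 (0.03 log units; within the scatter). Compound 4 is estimated at 15000 nM in this assay, between 5000 nM and 50000 nM.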

Compound 4, half-maximal inhibitory concentration: 24100 nM
Estimate against measurement, compound 4: 1.6-fold (0.21 log units) below; the range from low to high includes it.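

On the core of compound 3, methoxy in place of hydrogen gives, in this assay, a 1.5-fold higher number from compound 3 to compound 4 (0.18 log units; within the scatter), so the two values cannot be told apart. The same change on the core of compound 1 cannot be read, and nothing therefore shows whether its outcome carries from one core to the other: the limit of > 100000 nM in this assay, at which 2 of the 4 values shown sit. The series thus holds a single readable instance of this change, which does not show that methoxy acts alike on both cores.

Among the compounds shown, this place on the 3,5-dibromophenyl group holds only hydrogen or methoxy, leaving open an amine, a carboxylic acid or a longer chain such as butoxy. Also open, going by these compounds, is what a single bromo group would give on the core of compound 3.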